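A few compounds are considered here, and "the series" means these few. Any claim that something is new, unique, unknown or untested is made for them only; others in the source may bear on it.

Measured compounds: compound 1 `O=C(O)c1ccc(-c2cnc(C(=O)CCCCCCc3ccccc3)o2)cc1`, which in an assay (Rattus norvegicus) for inhibition of Fatty-acid amide hydrolase 1 (Homo sapiens) (on this read-out lower numbers stand for stronger inhibition and higher numbers for weaker inhibition), gives 60 nM; compound 2 `NC(=O)c1ccc(-c2cnc(C(=O)CCCCCCc3ccccc3)o2)cc1`, which gives 10 nM; and compound 3 `O=C(O)c1ccc(-c2cnc(C(O)CCCCCCc3ccccc3)o2)nc1`, which gives 45000 nM.

Compound 2 differs from compound 1 by amino in place of hydroxy on a carbonyl carbon, and that change gave a 6.0-fold lower number from compound 1 to compound 2 (0.78 log units; beyond the scatter). Compound 4 `NC(=O)c1ccc(-c2cnc(C(O)CCCCCCc3ccccc3)o2)nc1`, not yet measured, differs from compound 3 by amino in place of hydroxy on a carbonyl carbon, the same change at the same place. The difference between the cores of compound 1 and compound 3 is not broken down here. Compound 4 is expected to give 8000 nM in this assay, with a range from 2000 nM to 30000 nM. The expected step of a 5.6-fold lower number from compound 3 to compound 4 (0.75 log units; beyond the scatter) rests on the earlier 6.0-fold lower number from compound 1 to compound 2 (0.78 log units; beyond the scatter), while the wide range allows for the different cores.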

Compound 4, inhibition constant: 3000 nM
Compound 4: the middle estimate sits 2.7-fold (0.43 log units) above what was measured; low and high end bracket the measured number.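

The change of hydroxy to amino on a carbonyl carbon gave a 15-fold lower number from compound 3 to compound 4 (1.18 log units; beyond the scatter) in this assay. Set beside the earlier step, the change carried over to the second core in direction and, within the scatter, in size: the same change on two cores in this assay, a 6.0-fold lower number (0.78 log units; beyond the scatter) from compound 1 to compound 2 and a 15-fold lower number (1.18 log units; beyond the scatter) from compound 3 to compound 4, 2.5-fold (0.40 log units) apart, within the scatter of two such steps. This rests on two cores only and does not show that the step would hold on any other core, nor does it separate what the differences between those two cores contribute.

The compounds shown leave open how a methyl ester, a nitrile or a sulfonamide would compare with the carboxylic acid and the carbamoyl group at this place. Also open, going by these compounds, is whether the step would persist with a shorter or longer chain.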